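Ring stereocentre change from compound 2 to compound 3

The source may report more compounds than this note shows. Statements on the series, on what has been measured and on what is new or still open speak of the compounds shown alone.

Among the compounds with values here, in an ADME assay (Mus musculus, strain C57BL/6) for metabolic stability, read by HPLC, with a stated time of 12 h (a lower number here means that the compound disappears faster, a higher number that the compound lasts longer), compound 2 (`O=C(O)[C@H](CO)NC(=O)[C@@H]1C[C@H](O)CN1`) gives 1.15 h as the only exact number so far. Compound 1 (`O=C(O)[C@H](CO)NC(=O)[C@H]1C[C@H](O)CN1`) reads > 12 h as a limit of the assay. The change to compound 3 (`O=C(O)[C@H](CO)NC(=O)[C@@H]1C[C@@H](O)CN1`) is purely one of configuration (the two compounds have the same atoms and bonds and differ only in configuration as drawn: 1 of 3 stereo elements differ; a stereocentre at a saturated ring carbon is drawn S in compound 2 and R in compound 3). Within the data shown here, the single measured step (an at least 10-fold lower number from compound 1 to compound 2 (1.01 log units; beyond the scatter)) is also configurational and large, so configuration alone can matter (the fact that compounds 1 and 2 differ only in the configuration as drawn), but this one case sets no direction here. In this assay a step within the scatter is expected (a 1.3-fold lower number from compound 2 to compound 3 (0.11 log units; within the scatter)) with its direction open. Compound 3 is expected at 0.9 h with an estimated range of 0.3 h to 4 h for now.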

Compound 3, half-life: 0.88 h
The estimate for compound 3 lay 1.0-fold (0.01 log units) above the measured number; the range from low to high includes it.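

In this assay, the change at this ring stereocentre alone stays within the scatter: a 1.3-fold lower number from compound 2 to compound 3 (0.12 log units; within the scatter). With both ring stereocentres changed, the step is large (an at least 13-fold lower number from compound 1 to compound 3 (1.13 log units; beyond the scatter)), so among these three compounds, the large steps are those that include the stereocentre changed in an at least 10-fold lower number from compound 1 to compound 2 (1.01 log units; beyond the scatter). Compound 1 reads > 12 h, which is a limit of the assay and not a number.

On these data alone, whether this stereocentre matters as little with a methyl ether in place of the ring hydroxyl, or with a methyl ester in place of the carboxylic acid, stays open.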